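Adding a Second Fluorine to a Fluorinated Aniline Ring

The source may report more compounds than this note shows. Statements on the series, on what has been measured and on what is new or still open speak of the compounds shown alone.

Measured compounds:
- compound 1, `O=C1C(Nc2ccc(F)cc2F)=CC(=O)c2ncccc21`: 94%
- compound 2, `O=C1C(Nc2ccc(F)c(F)c2F)=CC(=O)c2ncccc21`: 72%
- compound 3, `O=C1C=C(Nc2cccc(F)c2)C(=O)c2cnccc21`: 89%

In a functional assay on the whole organism (aorta) with Rattus norvegicus as the target (a lower number here means a smaller maximal response, a higher number a larger maximal response), compound 1 gives 94%. Compound 2 differs from compound 1 by fluoro in place of hydrogen on an aromatic carbon, and this change made a number 22 percentage points lower from compound 1 to compound 2 (beyond the scatter). Compound 3 has a different core; the difference between the core of compound 3 and that of compound 1 is not broken down here. Compound 3 gives 89%, a number close to that of compound 1 and higher than that of compound 2.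

Compound 4, `O=C1C=C(Nc2cc(F)cc(F)c2)C(=O)c2cnccc21`, has not yet been measured. It differs from compound 3 by fluoro in place of hydrogen on an aromatic carbon. Among the compounds with values here, this is the same kind of change as the one from compound 1 to compound 2, but not the same: there the entering fluoro sat ortho to two fluoro groups, here it sits meta to a fluoro group, and the cores differ.

From compound 3 to compound 4 the expected step is a number 11 percentage points lower from compound 3 to compound 4 (beyond the scatter), resting on the step of a number 22 percentage points lower from compound 1 to compound 2 (beyond the scatter). The surroundings of the entering fluoro differ between the two changes, and a softened step is expected. For compound 4 the estimate in this assay is 78%, between 62% and 95%.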

Compound 4, largest response reached (Emax), in percent of the reference or control that the assay uses: 94%
Compound 4: middle estimate off by 16 percentage points, on the low side; the measured number falls inside the stated range.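

In this assay, fluoro in place of hydrogen, meta to a fluoro group, gives a number 5 percentage points higher from compound 3 to compound 4 (within the scatter), so compound 3 and compound 4 cannot be told apart here. The size of the step therefore did not carry over from one core to the other: the same change on two cores in this assay, a number 22 percentage points lower (beyond the scatter) from compound 1 to compound 2 and a number 5 percentage points higher (within the scatter) from compound 3 to compound 4, 27 percentage points apart, beyond the scatter of two such steps. This does not show why the steps differ, as the two changes differ both in the core and in the surroundings of the entering fluoro, and the compounds shown cannot separate these two differences; two steps also make no rule for the whole series.

Every substituent shown on the outer aromatic ring is fluoro, which leaves open how a chloro, methoxy or amino group at the same carbon would behave on either core. Also open, as far as these compounds go, is whether one and the same fluoro pattern would give matching numbers on the two cores.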